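From methyl to allyl at the limit of tolerance

The compounds below may be only part of what the source reports. "The series", "measured", "known", "first", "only" and "open" are said of these compounds alone.

compound 1 `Cc1cn([C@@H]2O[C@H](CO[Si](C)(C)C(C)(C)C)[C@@]3(OS(=O)(=O)C(Br)=C3N)[C@H]2O[Si](C)(C)C(C)(C)C)c(=O)[nH]c1=O`: 18000 nM
compound 2 `CNC1=C(C)S(=O)(=O)O[C@@]12[C@@H](CO[Si](C)(C)C(C)(C)C)O[C@@H](n1cc(C)c(=O)n(C)c1=O)[C@@H]2O[Si](C)(C)C(C)(C)C`: > 250000 nM
compound 3 `CC1=C(N)[C@@]2(OS1(=O)=O)[C@@H](CO[Si](C)(C)C(C)(C)C)O[C@@H](n1cc(C)c(=O)n(C)c1=O)[C@@H]2O[Si](C)(C)C(C)(C)C`: > 250000 nM

All three compounds were tested in a functional assay on MT4 cells (Homo sapiens) for cytotoxicity; a lower number here means that less compound is tolerated, a higher number that more compound is tolerated. Compound 3 gives > 250000 nM, which is a limit and not a number. Compound 2 also gives a limit, > 250000 nM. The upper end of this small set is therefore (the limit of > 250000 nM in this assay, at which 2 of the 3 values shown sit). Only compound 1 gives a number, 18000 nM, and it differs from compound 3 in more than one place.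

Compound 4 `C=CCC1=C(N)[C@@]2(OS1(=O)=O)[C@@H](CO[Si](C)(C)C(C)(C)C)O[C@@H](n1cc(C)c(=O)n(C)c1=O)[C@@H]2O[Si](C)(C)C(C)(C)C` departs from compound 3 by vinyl in place of hydrogen on a saturated chain carbon bound to a double-bonded ring carbon, which turns methyl into allyl. Within the data shown here, the only measured step, a step that the two limits leave unreadable from compound 2 to compound 3, concerns an amine nitrogen and has no readable size, so it offers no measured guide to this change. A result at the same limit remains quite possible, but the value of compound 1 shows that numbers can be read in this assay. The expected step is an at least 2.0-fold lower number from compound 3 to compound 4 (0.31 log units; beyond the scatter), towards less compound tolerated, and this expectation is tentative. For compound 4 the estimate is 120000 nM, with an expected range of 30000 nM to 250000 nM.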

Compound 4, half-maximal cytotoxic concentration: 82000 nM
The estimate for compound 4 lay 1.5-fold (0.17 log units) above the measured number; measured number inside the range.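

Turning methyl into allyl, with vinyl in place of hydrogen on a saturated chain carbon bound to a double-bonded ring carbon, gives the first readable change at this position: in this assay it is an at least 3.0-fold lower number from compound 3 to compound 4 (0.48 log units; beyond the scatter). Compound 3 gives > 250000 nM, which is a limit and not a number, so the true size of this step may be larger. The other step, on the amine nitrogen, cannot be read, which leaves this as the only change with a readable size, and the upper end of the set stands as follows: the limit of > 250000 nM in this assay, at which 2 of the 4 values shown sit.

As far as these compounds go, whether the double bond of the allyl group matters, or only the longer chain, stays open, as a propyl group at this place would be needed to separate the two. From the compounds shown here alone, whether a longer chain or a phenyl group would lower the number further in this assay also remains unknown.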